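A few compounds are considered here, and "the series" means these few. Any claim that something is new, unique, unknown or untested is made for them only; others in the source may bear on it.

Working notes on the series. Compound 1 `COc1cccc(OC)c1N1C(=O)CSC1c1cccc(C(=O)NCCCCc2ccccc2)c1` is tested in a functional assay on SJSA-1 cells (Homo sapiens) for inhibition, read by CCK-8 assay, with a stated time of 72 h, tested at 1 uM (on this read-out lower numbers stand for less inhibition and higher numbers for more inhibition at the one concentration tested (going by the name of the read-out)), and gives 72%. Going by the values given here, compound 2 `CCOc1ccccc1N1C(=O)C(C)SC1c1cccc(C(=O)NCCCCc2ccccc2)c1` gives 85% in this assay; the two compounds differ in more than one place, and the gap between their numbers lies beyond the usual scatter, so compound 1 stands lowest of the two numbers measured so far. Compound 3 `COc1cc(F)ccc1N1C(=O)CSC1c1cccc(C(=O)NCCCCc2ccccc2)c1` has not yet been measured in this assay. Relative to compound 1, the change is 4-fluoro-2-methoxyphenyl in place of 2,6-dimethoxyphenyl on an amide-type nitrogen in a ring. Among the compounds with values here, no measured pair shows this change on its own, and compound 2 offers no guide to it: its differences from compound 1 lie elsewhere. With nothing to anchor the change, the expected step is a number 2 percentage points lower from compound 1 to compound 3 (within the scatter), that is, none beyond the scatter in either direction. Compound 3 is estimated to give 70% in this assay, with a range from 50% to 85%.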

Compound 3, a percentage reported as inhibition, at one concentration (the size of the read-out at that concentration, not a potency): 77%
Compound 3: the middle estimate sits 7 percentage points below what was measured; the range from low to high includes it.
By their numbers in this assay, from the lowest: compounds 1, 3 and 2 (each within the scatter of the next, the first and the last beyond it).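

In this assay, 4-fluoro-2-methoxyphenyl in place of 2,6-dimethoxyphenyl on the amide-type nitrogen in the ring gives a number 5 percentage points higher from compound 1 to compound 3 (within the scatter). Going by these compounds alone, this is the first single-place reading at this position, and it shows that this exchange of phenyl substituents leaves the number within the scatter, so the 2,6-dimethoxy pattern is not required to keep the read-out at this level at the one concentration tested. No supporting measurement bears on why the two groups read alike.

The compounds shown leave open whether a group of a different kind at this position, such as a carboxylic acid or a dimethylamino group in place of the fluoro, would shift the number beyond the scatter. They also leave open whether a plain phenyl there would hold the number at this level.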